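This account rests on a few compounds, and the source may have more. Where it says the series, first, only, none or still open, it means among the compounds named here.

Measured in a physicochemical assay for solubility, using the shake flask method, measured as kinetic solubility, with a stated time of 2 h, at pH 7.4; a lower number here means a less soluble compound, a higher number a more soluble compound:
- compound 1 `O=C(Nc1ccccc1)c1cc(NCc2ccccc2)ncn1` gives < 5000 nM (a limit)
- compound 2 `CN(c1ccccc1)c1cc(C(=O)Nc2ccccc2)ncn1` gives < 5000 nM (a limit)
- compound 3 `CCN(Cc1ccc(Cl)cc1)c1cc(C(=O)Nc2ccccc2)ncn1` gives 5000 nM

Compound 2 has no number of its own, only a limit, and stands with compound 1 at the limit of < 5000 nM in this assay, at which 2 of the 3 values shown sit. Compound 3 is the only one of the three with a number, 5000 nM. For the measured compounds named here, no two measured compounds differ in one place only, so no measured step gives a size for the change to come.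

The next compound is compound 4 `CN(Cc1cccc(Cl)c1)c1cc(C(=O)Nc2ccccc2)ncn1`, which carries 3-chlorobenzyl in place of phenyl on a nitrogen on an aromatic ring. The nearest guide is compound 3, which also has a chlorobenzyl group on that nitrogen and reads 5000 nM. On that single reading, and with compound 2 reported only as a limit, no change beyond the usual scatter is expected in this assay, in either direction. The expected step is a number no lower from compound 2 to compound 4 (the limit leaves the size open), and the reading may again turn out to be only a limit. For compound 4 the estimate is 5000 nM, with an expected range of 2000 nM to 12000 nM.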

Compound 4, solubility: < 5000 nM
Compound 4: no number, only a limit; the forecaster's own chance of this, stated with the estimate: 65%; the middle value sits exactly at the limit.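

In this assay compound 4 gives < 5000 nM, which is a limit and not a number. For the compounds shown here, compound 2 also has only a limit, so no step between compound 2 and compound 4 can be read. The compounds shown leave open whether 3-chlorobenzyl in place of phenyl on this nitrogen changes the reading at all, with most values held at one limit: the limit of < 5000 nM in this assay, at which 3 of the 4 values shown sit.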